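From 2,4-dichlorophenyl to phenyl in compound 4

The source may report more compounds than this note shows. Statements on the series, on what has been measured and on what is new or still open speak of the compounds shown alone.

Measured so far in a functional assay on HUVEC cells (Homo sapiens) for inhibition; a lower number here means a stronger inhibitor, a higher number a weaker inhibitor
compound 1 `COc1cc(/C=C/C(=O)c2cccc(NC(=O)c3c(Cl)cccc3Cl)c2)ccc1O` gives 0.46 ug/mL
compound 2 `COc1cc(/C=C/C(=O)c2cccc(NC(=O)c3cc(Cl)cc(Cl)c3)c2)ccc1O` gives 0.75 ug/mL
compound 3 `COc1cc(/C=C/C(=O)c2cccc(NC(=O)c3ccc(Cl)cc3Cl)c2)ccc1O` gives 0.4 ug/mL

The three compounds differ only in the dichlorophenyl group on a carbonyl carbon. Compound 3 stands within the scatter of both other compounds (a 1.2-fold lower number from compound 1 to compound 3 (0.06 log units; within the scatter) and a 1.9-fold lower number from compound 2 to compound 3 (0.27 log units; within the scatter)). The remaining step (a 1.6-fold higher number from compound 1 to compound 2 (0.21 log units; within the scatter)) also stays within the scatter, so these data do not separate the three dichlorophenyl groups.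

Compound 4 `COc1cc(/C=C/C(=O)c2cccc(NC(=O)c3ccccc3)c2)ccc1O` is still unmeasured. It carries phenyl in place of 2,4-dichlorophenyl on a carbonyl carbon and otherwise keeps the core of compound 3. Going by the values given here, no measured step removes chlorine, so the three steps bear on this change only indirectly. Each exchanges one dichlorophenyl group for another, and the largest (a 1.9-fold lower number from compound 2 to compound 3 (0.27 log units; within the scatter)) remains within the scatter. A small step in this assay is therefore expected, with a slight lean toward a higher number, though the data cannot exclude a larger one. The estimated step is a 1.6-fold higher number from compound 3 to compound 4 (0.21 log units; within the scatter) and it is the working expectation. Compound 4 is estimated at 0.65 ug/mL with an expected range from 0.28 ug/mL to 1.5 ug/mL for the coming measurement.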

Compound 4, half-maximal inhibitory concentration: 0.37 ug/mL
For compound 4 the middle estimate is 1.8-fold (0.24 log units) above the measured one; measured number inside the range.
By their numbers in this assay, from the lowest: compounds 4, 3, 1 and 2 (each within the scatter of the next, the first and the last beyond it).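

In this assay the chlorine atoms are not required on this group on the carbonyl carbon: phenyl in place of 2,4-dichlorophenyl (a 1.1-fold lower number from compound 3 to compound 4 (0.03 log units; within the scatter)) and phenyl in place of 2,6-dichlorophenyl (a 1.2-fold lower number from compound 1 to compound 4 (0.09 log units; within the scatter)) both stay within the scatter. Phenyl in place of 3,5-dichlorophenyl (a 2.0-fold lower number from compound 2 to compound 4 (0.31 log units; beyond the scatter)) is the one step in this set that lies beyond the scatter, though only modestly, and none of the three dichlorophenyl groups gives a number beyond the scatter below that of compound 4. No measurement at hand accounts for these steps.

Still open, as far as these compounds go, is whether the position tolerates more than phenyl and its dichloro forms, for example a ring carrying an amine or a carboxylic acid, or cyclohexyl in place of the aromatic ring. Also open, from the compounds shown here alone, is how a single chlorine or a methoxy group on the phenyl would read against compound 4, given that the steps seen so far are small.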